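The source may report more compounds than this note shows. Statements on the series, on what has been measured and on what is new or still open speak of the compounds shown alone.

Compound 2 `Cc1ccc(-c2cn(C/C=C3\OC(=O)C(OCc4ccccc4)=C3OCc3ccccc3)nn2)cc1` is the starting point. In a functional assay on HeLa cells (Homo sapiens) for antiproliferative activity, read by MTT assay, with a stated time of 72 h (a lower number here means a stronger inhibitor, a higher number a weaker inhibitor), compound 2 gives 7480 nM, the lowest of the two numbers recorded; compound 1 `O=C1O[C@H]([C@@H](O)Cn2cc(-c3cc(F)cc(F)c3)nn2)C(OCc2ccccc2)=C1OCc1ccccc1` gives 40800 nM, a higher number that lies beyond the scatter. Compound 3 `COc1ccccc1-c1cn(C[C@H](O)[C@H]2OC(=O)C(OCc3ccccc3)=C2OCc2ccccc2)nn1` is recorded only as a limit of the assay, > 100000 nM, so no number is known for it. Within the data shown here, the one measured change with a single alteration runs from compound 1 to compound 3, where 2-methoxyphenyl in place of 3,5-difluorophenyl on an aromatic carbon gives an at least 2.4-fold higher number from compound 1 to compound 3 (0.38 log units; beyond the scatter), a result set by the limit of > 100000 nM in this assay, at which 1 of the 3 values shown sits, rather than by a number.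

Compound 4 `COc1ccccc1-c1cn(C/C=C2\OC(=O)C(OCc3ccccc3)=C2OCc2ccccc2)nn1` has not been measured. It differs from compound 2 in a single place: 2-methoxyphenyl in place of 4-methylphenyl on an aromatic carbon. The measured step shares the group that enters, 2-methoxyphenyl, though the group that leaves there was different, so it bears on this step only in part. Its direction was toward a weaker inhibitor, and by at least a modest amount, so a rise beyond the scatter is expected here too, with wide uncertainty. For compound 4 the expected value in this assay is 30000 nM, within 9000 nM to 100000 nM, corresponding to an estimated step of a 4.0-fold higher number from compound 2 to compound 4 (0.60 log units; beyond the scatter) from compound 2.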

Compound 4, half-maximal inhibitory concentration: > 100000 nM
Compound 4: only a limit was reported; the forecaster's own chance of this, stated with the estimate: 25%; middle value at least 3.3-fold (0.52 log units) away from the limit.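

In this assay, the exchange of 4-methylphenyl for 2-methoxyphenyl gives an at least 13-fold higher number from compound 2 to compound 4 (1.12 log units; beyond the scatter), which shows that this aromatic carbon of the five-membered ring is sensitive to the group it carries, at least on the side chain of compound 2. The earlier step brought in 2-methoxyphenyl only in place of 3,5-difluorophenyl, whereas this one shows a rise beyond the scatter from a different starting group and on a different side chain, so the loss is not tied to one pair of compounds. Compound 4 is recorded as > 100000 nM, which is a limit of the assay and not a number, and the true size of the step stays unknown, as it does for the other compound carrying 2-methoxyphenyl: the limit of > 100000 nM in this assay, at which 2 of the 4 values shown sit.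

From the compounds shown here alone, whether the loss follows the methoxy group itself or its place on the phenyl ring stays open, and a 4-methoxyphenyl or a plain phenyl at this position would help to separate the two. Also open, going by these compounds, is how a ring carrying an amine or a carboxylic acid would behave here, set against the 4-methylphenyl of compound 2.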